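This account rests on a few compounds, and the source may have more. Where it says the series, first, only, none or still open, it means among the compounds named here.

Measured so far:
- compound 1 `C[C@@]1(O)CC(=O)OC(CSc2nc(-c3cccc(Cl)c3)c(-c3cccc(Cl)c3)[nH]2)C1` — in an assay on microsomes from liver for inhibition of sterol O-acyltransferase 1 (Rattus norvegicus) (on this read-out lower numbers stand for stronger inhibition and higher numbers for weaker inhibition), compound 1 gives 110 nM
- compound 2 `CC1=CC(=O)OC(CSc2nc(-c3ccccc3)c(-c3ccccc3)[nH]2)C1` — in this assay compound 2 gives 200 nM

For the measured compounds named here, compound 1 holds the lower of the two numbers, with compound 2 as its only neighbour; the two values lie within the scatter of each other, so neither compound can be called the stronger inhibitor on this evidence. Going by the values given here, no step between measured compounds that differ in a single place is available, so there is no direct read on how any one change moves the numbers.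

Compound 3 `CC1=CC(=O)OC(CSc2nc(-c3cccc(Cl)c3)c(-c3cccc(Cl)c3)[nH]2)C1` is not yet measured. Compared with compound 1, the change is a group of 8 heavy atoms (6 carbon, 2 oxygen; one six-membered non-aromatic ring with 1 hetero atom) in place of a group of 9 heavy atoms (6 carbon, 3 oxygen; one six-membered non-aromatic ring with 1 hetero atom), on a saturated chain carbon bound to a sulfur. Among the compounds with values here, since no measured pair isolates this exchange, nothing here tells whether it raises or lowers the number; compound 2, which carries the entering group but differs from compound 3 elsewhere, sits within the scatter of compound 1. The expectation for this assay is therefore a step of no more than the usual scatter in either direction, with compound 3 estimated at 130 nM (range 50 nM to 350 nM), which would mean an expected step of a 1.2-fold higher number from compound 1 to compound 3 (0.07 log units; within the scatter).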

Compound 3, half-maximal inhibitory concentration: 440 nM
Compound 3: middle estimate off by 3.4-fold (0.53 log units), on the low side; measured number above the stated range.
By their numbers in this assay, from the lowest: compounds 1 and 2 (each within the scatter of the next); then compound 3.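

For the compounds shown here, with compound 3, the exchange on a saturated chain carbon bound to a sulfur can be read directly for the first time: in this assay it gives a 4.0-fold higher number from compound 1 to compound 3 (0.60 log units; beyond the scatter) with the rest of the structure unchanged. This position is therefore not indifferent to the group it carries, and the group that leaves, with 1 hydrogen-bond donor and 1 defined stereocentre, goes with the lower number even though the two groups differ by only a single heavy atom. The data shown offer nothing that explains this step.

The compounds shown leave open which of the counted differences between the two groups, the hydrogen-bond donor, the defined stereocentre or the additional double bond, carries the step, and whether the same exchange gives a similar step on the core of compound 2. They also leave open how a carboxylic acid or an amine on a saturated chain carbon bound to a sulfur, in place of either six-membered ring, would read in this assay on this core.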